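This account rests on a few compounds, and the source may have more. Where it says the series, first, only, none or still open, it means among the compounds named here.

Compound 1 `CCOC(=O)c1sc(NC(=O)Cn2cc(-c3cccs3)nn2)nc1C` is measured in a functional assay on BMDM cells (Mus musculus, strain C57BL/6) for inhibition, with a stated time of 2 days (a lower number here means a stronger inhibitor, a higher number a weaker inhibitor), where compound 1 gives 20 nM. Compound 2 `CCOC(=O)c1sc(NC(=O)Cn2cc(-c3ccc(F)cc3)nn2)nc1C` differs from compound 1 by 4-fluorophenyl in place of thiophen-2-yl on an aromatic carbon, and in this assay compound 2 gives 660 nM. That step, a 33-fold higher number from compound 1 to compound 2 (1.52 log units; beyond the scatter), is a large loss of potency.

Compound 3 `O=C(Cn1cc(-c2cccs2)nn1)Nc1nccs1` carries a smaller core than compound 1; how the two cores differ is not broken down here. In this assay compound 3 is reported only as a limit, > 30000 nM. Compound 3 sits at the limit of > 30000 nM in this assay, at which 1 of the 3 values shown sits.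

Compound 4 `O=C(Cn1cc(-c2ccc(F)cc2)nn1)Nc1nccs1`, not yet measured, differs from compound 3 by 4-fluorophenyl in place of thiophen-2-yl on an aromatic carbon. Going by the values given here, this is the same kind of change as the one from compound 1 to compound 2, the surroundings differing only in that the ring atom two ring bonds away bears a group of 9 heavy atoms rather than a large group. A step of roughly the same direction is expected, a step that the limit leaves unreadable from compound 3 to compound 4, resting on a 33-fold higher number from compound 1 to compound 2 (1.52 log units; beyond the scatter). For compound 4 the estimate in this assay is 100000 nM, most likely again a limit.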

Compound 4, half-maximal inhibitory concentration: 190 nM
The estimate for compound 4 lay 530-fold (2.72 log units) above the measured number; measured number below the stated range.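

In this assay, putting 4-fluorophenyl in place of thiophen-2-yl gives an at least 150-fold lower number from compound 3 to compound 4 (2.19 log units; beyond the scatter), so on this smaller core the change strengthens inhibition, whereas on the core of compound 1 it weakened inhibition, and the two results clearly disagree: the same change on two cores in this assay, a 33-fold higher number (1.52 log units; beyond the scatter) from compound 1 to compound 2 and an at least 150-fold lower number (2.19 log units; beyond the scatter) from compound 3 to compound 4, at least 5200-fold (3.71 log units) apart, beyond the scatter of two such steps

Compound 3 is reported only as a limit, > 30000 nM, and not as a number. Going by these compounds alone, the two steps show that, in these four compounds, the result of this change depends on the core and cannot simply be carried from one core to the other, but with only two cores they do not show which part of the core matters or give a rule for other cores.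

Going by these compounds, it stays open whether the ethyl ester, the methyl group or both together on the core of compound 1 go with the opposite results. Also open, on these data alone, is how a plain phenyl group on either core, or a carboxylic acid in place of the ethyl ester, would behave.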